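Benzylsulfanyl in place of propylsulfanyl on the triazole series

A few compounds are considered here, and "the series" means these few. Any claim that something is new, unique, unknown or untested is made for them only; others in the source may bear on it.

Measured compounds:
compound 1, `Clc1ccc(Cc2nnc(SCc3ccccc3)[nH]2)c(Oc2ccccc2Cl)c1`, 129%
compound 2, `CSc1nnc(Cc2ccc(Cl)cc2Oc2ccccc2F)[nH]1`, 136%
compound 3, `CCCSc1nnc(Cc2ccc(Cl)cc2Oc2ccccc2F)[nH]1`, 133%

Of the compounds shown here, three have been measured in a functional assay on the whole organism (strain NMRI) with Mus musculus as the target, with a stated time of 60 min, at a dose of 20 mg/kg by the intraperitoneal route; on this read-out lower numbers stand for a weaker effect and higher numbers for a stronger effect at the one dose given. Compound 3 stands second highest of the three numbers; its nearest neighbour is compound 2, and the furthest is compound 1, and both lie within the scatter of compound 3. Among the compounds with values here, the one step between measured compounds that differ in one place, a number 3 percentage points lower from compound 2 to compound 3 (within the scatter), is within the scatter, so a change on the saturated chain carbon bound to a sulfur has so far left the read-out unmoved.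

Compound 4, `Fc1ccccc1Oc1cc(Cl)ccc1Cc1nnc(SCc2ccccc2)[nH]1`, has not yet been measured. It differs from compound 3 by phenyl in place of ethyl on a saturated chain carbon bound to a sulfur. Within the data shown here, no measured step covers this change exactly. Compound 1 carries the same benzylsulfanyl group on a core that differs elsewhere, and in this assay compound 1 gives 129%, which is within the scatter of compound 3. Taken together, the step from compound 2 to compound 3 and the value of compound 1 give no reason to expect a step beyond the scatter.

Compound 4 is therefore expected to give 131% in this assay, with a range from 116% to 146%. The expected step is a number 2 percentage points lower from compound 3 to compound 4 (within the scatter).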

Compound 4, a percentage reported as activity, at one dose (the size of the read-out at that dose, not a potency): 179%
Beside the measured number, compound 4's estimate is 48 percentage points below it; measured number above the stated range.
By their numbers in this assay, from the lowest: compounds 1, 3 and 2 (each within the scatter of the next); then compound 4.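

In this assay, phenyl in place of ethyl on a saturated chain carbon bound to a sulfur, which is propylsulfanyl to benzylsulfanyl, gives a number 46 percentage points higher from compound 3 to compound 4 (beyond the scatter), and phenyl in place of hydrogen at the same place gives a number 43 percentage points higher from compound 2 to compound 4 (beyond the scatter), so this position, which showed no response to ethyl in place of hydrogen, does respond to phenyl. The benzylsulfanyl group does not settle the number on its own, since fluoro in place of chloro on an aromatic carbon gives a number 50 percentage points higher from compound 1 to compound 4 (beyond the scatter), which ties the high read-out to the fluoro as well as to the phenyl. Nothing available gives a reason for the size of either change.

On these data alone, it remains open whether the aromatic ring itself matters or any larger group at this place would serve, which a cyclohexylmethyl group or a longer chain such as phenethyl in place of benzyl would help to tell. The read-out comes from a single dose, so it also leaves open how these differences would look across a range of doses.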